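The source may report more compounds than this note shows. Statements on the series, on what has been measured and on what is new or still open speak of the compounds shown alone.

Compound 1 `CC1(OC(=O)N2CC3COCC(C2)C3Oc2ncnc(Oc3ccccc3F)c2F)CC1`: 136%
Compound 2 `CCC1(OC(=O)N2CC3COCC(C2)C3Oc2ncnc(Nc3ccc(C#N)cc3F)c2F)CC1`: 90%
Compound 3 `CC1(OC(=O)N2C[C@H]3COC[C@@H](C2)[C@@H]3Oc2ncnc(Nc3c(F)cccc3F)c2F)CC1`: 108%

These three compounds were tested in a functional assay for agonist activity at Glucose-dependent insulinotropic receptor (Mus musculus), read by cAMP accumulation; a higher number here means a larger maximal response, a lower number a smaller maximal response. Compound 2 has the lowest of the three numbers: compound 3 stands higher by more than the usual scatter, and compound 1 stands higher still, also beyond the scatter.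

Compound 4 `COCC1(OC(=O)N2CC3COCC(C2)C3Oc2ncnc(Nc3ccc(C#N)cc3F)c2F)CC1` has not yet been measured. It differs from compound 2 in one place: methoxy in place of methyl on a saturated chain carbon bound to a saturated ring carbon. For the measured compounds named here, no measured pair shows this same change, so its effect cannot be read off from the data at hand. Since the change adds only one atom to a side group, the step from compound 2 is expected to stay within the usual scatter, in no clear direction; the expected step is a number 5 percentage points higher from compound 2 to compound 4 (within the scatter). Compound 4 is therefore estimated to reach 95%, with a range from 70% to 120%.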

Compound 4, largest response reached (reported as percent of maximum), in percent of the reference or control that the assay uses: 70%
Compound 4: middle estimate off by 25 percentage points, on the high side; measured number inside the range.
By their numbers in this assay, from the lowest: compound 4; then compound 2; then compound 3; then compound 1.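

In this assay, methoxy in place of methyl on a saturated chain carbon bound to a saturated ring carbon gives a number 20 percentage points lower from compound 2 to compound 4 (beyond the scatter). For the compounds shown here, this is the first pair here that differs in one place, and it shows that the maximal response can shift with even this small change to the side group. No available data bear on why the response falls.

This single pair cannot separate the effect of the added oxygen from that of the longer side group. As far as these compounds go, whether a propyl or hydroxymethyl group in this place would lower the response too remains open.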